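The source may hold more compounds than are shown below. What is called first, only, known or untested is meant among the compounds shown, and "the series" means these compounds.

Compound 1 `Clc1ccc2c(-n3cc(C4CCCCC4)nn3)ccnc2c1` in an ADME assay on HepG2 cells (Homo sapiens) for cytotoxicity, read by MTT assay, with a stated time of 24 h (a higher number here means that more compound is tolerated, a lower number that less compound is tolerated), gives > 3200 nM, which is a limit of the assay rather than a number.
Compound 2 `COc1ccc2cc(-c3cn(-c4ccnc5cc(Cl)ccc45)nn3)ccc2c1` gives > 2590000 nM, also a limit.
Compound 3 `CCc1ccc(C(=O)OCc2cn(-c3ccnc4cc(Cl)ccc34)nn2)cc1` gives > 2550000 nM, again a limit.

All three values shown are limits, so compound 3 stands among them without a number of its own; the limit of > 2550000 nM in this assay, at which 1 of the 3 values shown sits, marks the limit at which it sits, one of three such limits. Compound 4 `COc1ccc(C(=O)OCc2cn(-c3ccnc4cc(Cl)ccc34)nn2)cc1` differs from compound 3 by methoxy in place of ethyl on an aromatic carbon. Going by the values given here, no measured step between compounds is available to lean on, so the step from compound 3 to compound 4 in this assay is expected to be none beyond the usual scatter, with compound 4 expected to reach a limit again. The estimate for compound 4 is 2550000 nM, between 1000000 nM and 5000000 nM. This estimate means an expected step of a number no higher from compound 3 to compound 4 (the limit leaves the size open).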

Compound 4, half-maximal cytotoxic concentration: 303000 nM
Beside the measured number, compound 4's estimate is 8.4-fold (0.93 log units) above it; measured number outside the range, below it.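

At this aromatic carbon, para to a large group, methoxy in place of ethyl is not a neutral change: this assay shows an at least 8.4-fold lower number from compound 3 to compound 4 (0.92 log units; beyond the scatter), beyond the usual scatter. Going by these compounds alone, compound 4 is also the first compound here with a true number rather than a limit, and the real size of the step stays open since the value of compound 3 is a limit. Nothing at hand explains the drop.

Open, on these data alone, is how an amine, a hydroxyl group or a longer chain would fare at this position. Also open, as far as these compounds go, is whether this change would act alike on other compounds.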